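The source may hold more compounds than are shown below. What is called first, only, known or untested is meant among the compounds shown, and "the series" means these compounds.

Going by the values given here, the shared core of this set carries an amine nitrogen whose substituent is the only thing that changes. Compound 1, `O=C1C=C(Nc2ccc(I)cc2)C(=O)c2c1nc1n2[C@H]2OC[C@@H](O)[C@H]2OC1`, bears 4-iodophenyl there, and in a functional assay on MGC-803 cells (Homo sapiens) for inhibition, read by sulforhodamine B assay (on this read-out lower numbers stand for stronger inhibition and higher numbers for weaker inhibition), compound 1 gives 1400 nM. Compound 2, `O=C1C=C(Nc2cccc(Cl)c2)C(=O)c2c1nc1n2[C@H]2OC[C@@H](O)[C@H]2OC1`, bears 3-chlorophenyl, and in this assay compound 2 gives 1770 nM; the step of a 1.3-fold higher number from compound 1 to compound 2 (0.10 log units; within the scatter) separates them. Compound 3, `O=C1C=C(NC2CCCC2)C(=O)c2c1nc1n2[C@H]2OC[C@@H](O)[C@H]2OC1`, carries cyclopentyl on the amine nitrogen. For compound 3 this assay reports only a limit, > 8000 nM, so compound 3 stands at the limit of > 8000 nM in this assay, at which 1 of the 3 values shown sits, rather than at a number. The two steps that reach it, an at least 5.7-fold higher number from compound 1 to compound 3 (0.75 log units; beyond the scatter) and an at least 4.5-fold higher number from compound 2 to compound 3 (0.65 log units; beyond the scatter), both run towards weaker inhibition when 4-iodophenyl or 3-chlorophenyl is exchanged for cyclopentyl.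

Compound 4, `O=C1C=C(NC2CCCCC2)C(=O)c2c1nc1n2[C@H]2OC[C@@H](O)[C@H]2OC1`, differs from compound 3 by cyclohexyl in place of cyclopentyl on an amine nitrogen. Among the compounds with values here, no measured step in this set exchanges one non-aromatic ring of carbon only for another, so the steps that bear on the question are those into compound 3, which were at least modest and ended at a limit. A ring of this kind remains on the amine nitrogen, and the resulting step is expected to be a step that the limit leaves unreadable from compound 3 to compound 4, within the scatter. The estimate for compound 4 in this assay is therefore 12000 nM, within 5000 nM to 30000 nM, with a good chance that again only a limit is reported.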

Compound 4, half-maximal inhibitory concentration: > 8000 nM
Compound 4: only a limit was reported; the forecaster's own chance of this, stated with the estimate: 75%; the middle value lies beyond the limit too.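

Compound 4 shows that the drop seen with cyclopentyl on the amine nitrogen is not tied to that one ring: in this assay, cyclohexyl gives an at least 4.5-fold higher number from compound 2 to compound 4 (0.65 log units; beyond the scatter) and also an at least 5.7-fold higher number from compound 1 to compound 4 (0.75 log units; beyond the scatter). Among the four compounds shown, the split now follows the kind of ring, with 4-iodophenyl and 3-chlorophenyl giving measured numbers and both non-aromatic rings of carbon only giving limits, and no compound shown goes against it. Compound 3 and compound 4 each end at a limit rather than a number, so the step between them cannot be read, and the limit is now shared: the limit of > 8000 nM in this assay, at which 2 of the 4 values shown sit.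

On these data alone, whether cyclopentyl and cyclohexyl differ at all in this assay therefore remains open, as does how far above the limit either compound lies. As far as these compounds go, it is also open whether the aromatic ring alone carries the measurable inhibition or its halogen matters too, which unsubstituted phenyl on the same amine nitrogen would address, while benzyl would test whether the aromatic ring must sit directly on that nitrogen.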